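A few compounds are considered here, and "the series" means these few. Any claim that something is new, unique, unknown or untested is made for them only; others in the source may bear on it.

Compound 1 `CCCCOC(=O)Nc1ccc([Se]C#N)cc1` and compound 2 `N#C[Se]c1ccc(NC(=O)Oc2ccc(Cl)cc2)cc1` share a core and were both examined in a functional assay on HT-29 cells (Homo sapiens) for cytotoxicity, read by MTT assay, with a stated time of 72 h; on this read-out higher numbers stand for lower toxicity in this test and lower numbers for higher toxicity in this test. In this assay compound 1 gives 63700 nM, and compound 2 gives 68700 nM, a value within the scatter of that of compound 1, so neither can be set apart from the other. Compound 3 `N#C[Se]c1ccc(NC(=O)OCc2ccccc2)cc1` has not yet been measured and differs from compound 1 by phenyl in place of propyl on a saturated chain carbon bound to an oxygen next to a carbonyl group. Among the measured compounds shown here, no measured pair shows this change, so its size is unknown from the data, and the two numbers in hand point in no direction. The step that this estimate means is expected to be a 1.1-fold lower number from compound 1 to compound 3 (0.03 log units; within the scatter), within the scatter. Compound 3 is therefore expected to give 60000 nM, between 25000 nM and 150000 nM.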

Compound 3, concentration lethal to 50% of the cells: 69100 nM
Compound 3: middle estimate off by 1.2-fold (0.06 log units), on the low side; the range from low to high includes it.
By their numbers in this assay, from the lowest: compounds 1, 2 and 3 (each within the scatter of the next).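

In this assay, phenyl in place of propyl on a saturated chain carbon bound to an oxygen next to a carbonyl group gives a 1.1-fold higher number from compound 1 to compound 3 (0.04 log units; within the scatter), the first step measured at this position. At this place, then, an open chain and a six-membered aromatic ring of carbon only cannot be told apart in this test. No measured evidence is available to explain this result.

The compounds shown leave open whether an amine, a carboxylic acid or a much longer chain at this place would move the number beyond the scatter. They also leave open what a change at any other place on the shared core would do.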